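The compounds below may be only part of what the source reports. "The series", "measured", "known", "first", "only" and "open" are said of these compounds alone.

Two ureas anchor this comparison. Compound 1 `Cc1cc(NC(=O)Nc2ccc(C(=O)O)cc2)c2ccccc2n1` and compound 2 `CSc1ccccc1NC(=O)Nc1cc(C)nc2ccccc12` share the same core, and both have been tested in an ADME assay on HepG2 cells (Homo sapiens) for cytotoxicity, with a stated time of 72 h; a lower number here means that less compound is needed, a higher number that more compound is needed for the effect. In that assay compound 1 reaches only the limit > 25000 nM. Compound 2 likewise stops at the limit > 25000 nM, so no number is known for it. Both values sit at the limit of > 25000 nM in this assay, at which 2 of the 2 values shown sit. Compound 3 `COc1ccccc1NC(=O)Nc1cc(C)nc2ccccc12` differs from compound 2 in one place: methoxy in place of methylsulfanyl on an aromatic carbon. With two limits behind it and such a small change, no step beyond the scatter is expected; the estimated step is a step that the limit leaves unreadable from compound 2 to compound 3. Compound 3 is therefore expected to give about 30000 nM, between 15000 nM and 60000 nM, most likely again as a limit.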

Compound 3, half-maximal effective concentration: > 25000 nM
Compound 3 ended at the assay's limit; the forecaster's own chance of this, stated with the estimate: 80%; the middle value lies beyond the limit too.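

Compound 2 and compound 3 both stop at a limit in this assay, so no step between them can be read: the limit of > 25000 nM in this assay, at which 3 of the 3 values shown sit.

What these compounds leave open is how methoxy and methylsulfanyl compare at concentrations past that limit.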